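Methoxy added beside the phenolic hydroxy of a thiosemicarbazone

This account rests on a few compounds, and the source may have more. Where it says the series, first, only, none or still open, it means among the compounds named here.

Compound 1, `CC1=CC[C@H](C(C)(C)NC(=S)N/N=C/c2ccc(O)cc2)CC1`, in a functional assay on OVCAR-3 cells (Homo sapiens) for inhibition, read by sulforhodamine B assay, with a stated time of 48 h (on this read-out higher numbers stand for weaker inhibition of growth and lower numbers for stronger inhibition of growth), gives > 100000 nM, a limit of the assay rather than a number.
Compound 2, `CC1=CC[C@H](C(C)(C)NC(=S)N/N=C/c2ccc(F)cc2)CC1`, in this assay gives > 100000 nM, again a limit.

Among the measured compounds shown here, compound 1 thus stands only at a limit, and the one other value shown is a limit as well. The step that the two limits leave unreadable from compound 1 to compound 2 cannot be read, because the limit of > 100000 nM in this assay, at which 2 of the 2 values shown sit, holds both values. Compound 3, `COc1cc(/C=N/NC(=S)NC(C)(C)[C@H]2CC=C(C)CC2)ccc1O`, differs from compound 1 by methoxy in place of hydrogen on an aromatic carbon, a methoxy entering ortho to a hydroxy group on the same ring. For the measured compounds named here, no measured step bears on this change, and nothing measured shows any member of this set reaching a number. Compound 3 is therefore expected to give 100000 nM, most likely reported again as a limit, with a range of 30000 nM to 300000 nM. The step from compound 1 to compound 3 is estimated as a number no higher from compound 1 to compound 3 (the limit leaves the size open), not beyond the scatter.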

Compound 3, concentration for total growth inhibition: > 100000 nM
Compound 3 gave a limit, no number; the forecaster's own chance of this, stated with the estimate: 85%; the middle value sits exactly at the limit.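

Compound 3 also sits at a limit, so the step from compound 1 to compound 3 cannot be read and no size can be given for the added methoxy: the limit of > 100000 nM in this assay, at which 3 of the 3 values shown sit.

The compounds shown leave open whether any close relative reaches an actual number in this assay, and so what the methoxy contributes there.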